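Cyano for carbamoyl on the compound 2 side chain

This account rests on a few compounds, and the source may have more. Where it says the series, first, only, none or still open, it means among the compounds named here.

In a functional assay (trachea) with Cavia porcellus as the target (a lower number here means that less compound is needed, a higher number that more compound is needed for the effect), compound 1 (`CCCn1c(=O)n(C)c(=O)c2c1ncn2CCC(=O)O`) gives > 100000 nM, which is a limit. Compound 2 (`CCCn1c(=O)n(C)c(=O)c2c1ncn2CC(N)=O`) gives > 100000 nM, likewise only a limit. Compound 3 (`CCCn1c(=O)n(C)c(=O)c2c1ncn2CC#N`) differs from compound 2 by cyano in place of carbamoyl on a saturated chain carbon bound to an aromatic nitrogen, cyano in place of carbamoyl. Going by the values given here, the one measured step bearing on this, a step that the two limits leave unreadable from compound 1 to compound 2, has no readable size, and the only evidence is the limit of > 100000 nM in this assay, at which 2 of the 2 values shown sit. No direction can be drawn from it, so the expected step, a number no higher from compound 2 to compound 3 (the limit leaves the size open), is small. Compound 3 is estimated at 100000 nM, with an expected range of 30000 nM to 300000 nM.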

Compound 3, half-maximal effective concentration: 35300 nM
Estimate against measurement, compound 3: 2.8-fold (0.45 log units) above, and the stated range covers the measured number.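

Going by these compounds alone, on the saturated chain carbon bound to an aromatic nitrogen, cyano gives the first readable number in this assay, with an at least 2.8-fold lower number from compound 2 to compound 3 (0.45 log units; beyond the scatter). Cyano in place of carboxymethyl reads the same way, with an at least 2.8-fold lower number from compound 1 to compound 3 (0.45 log units; beyond the scatter). Both steps are open-ended, and the step between compound 1 and compound 2 cannot be read, since those two compounds stand only as limits: the limit of > 100000 nM in this assay, at which 2 of the 3 values shown sit.

Going by these compounds, the true size of both steps stays open. Also open, on these data alone, is whether a longer chain ending in cyano, an amine or a tetrazole at this place would lower the number further.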